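This account rests on a few compounds, and the source may have more. Where it says the series, first, only, none or still open, it means among the compounds named here.

Compound 1 `Cc1ccc(S(=O)(=O)/C(=C/c2ccc(O)c([N+](=O)[O-])c2)C(=O)c2ccc(Cl)cc2)cc1` carries a 4-hydroxy-3-nitrophenyl group, and in a functional assay on DU-145 cells (Homo sapiens) for inhibition, read by trypan blue exclusion, with a stated time of 96 h (a higher number here means a weaker inhibitor of growth, a lower number a stronger inhibitor of growth), compound 1 gives 25000 nM. Compound 2 `COc1ccc(/C=C(\C(=O)c2ccc(Cl)cc2)S(=O)(=O)c2ccc(C)cc2)cc1O` differs by 3-hydroxy-4-methoxyphenyl in place of 4-hydroxy-3-nitrophenyl on a double-bonded chain carbon bound to a double-bonded chain carbon and in this assay compound 2 gives 1000 nM; that change brings a 25-fold lower number from compound 1 to compound 2 (1.40 log units; beyond the scatter). Compound 3 `O=C(O)c1ccc(C(=O)/C(=C\c2ccc(O)c([N+](=O)[O-])c2)SCc2ccc(F)cc2)cc1` rests on a different core, and the difference between the two cores is not broken down here. In this assay compound 3 reaches only a limit of the assay, > 100000 nM, which is the limit of > 100000 nM in this assay, at which 1 of the 3 values shown sits. Compound 4 `COc1ccc(/C=C(/SCc2ccc(F)cc2)C(=O)c2ccc(C(=O)O)cc2)cc1O` differs from compound 3 by 3-hydroxy-4-methoxyphenyl in place of 4-hydroxy-3-nitrophenyl on a double-bonded chain carbon bound to a double-bonded chain carbon, the same change as between compound 1 and compound 2. A step of similar size is expected, an at least 5.0-fold lower number from compound 3 to compound 4 (0.69 log units; beyond the scatter), because the earlier change gave a 25-fold lower number from compound 1 to compound 2 (1.40 log units; beyond the scatter), though starting from a limit leaves the outcome uncertain. Compound 4 is therefore estimated at 20000 nM, between 3000 nM and 100000 nM.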

Compound 4, concentration for 50% growth inhibition: 10000 nM
Beside the measured number, compound 4's estimate is 2.0-fold (0.30 log units) above it; the measured number falls inside the stated range.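

Putting 3-hydroxy-4-methoxyphenyl in place of 4-hydroxy-3-nitrophenyl also lowers the number on the second core in this assay, giving an at least 10-fold lower number from compound 3 to compound 4 (1.00 log units; beyond the scatter), so the direction of the change carries over between these two cores. Its size may or may not carry over, and two cores say nothing about any others: the same change on two cores in this assay, a 25-fold lower number (1.40 log units; beyond the scatter) from compound 1 to compound 2 and an at least 10-fold lower number (1.00 log units; beyond the scatter) from compound 3 to compound 4; the limit leaves it open whether they differ. Compound 3 stands at a limit of the assay, not at a measured number: the limit of > 100000 nM in this assay, at which 1 of the 4 values shown sits.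

In both pairs the nitro group leaves and the methoxy group enters together, so the compounds shown leave open which of the two matters more. They also leave open how a phenyl ring carrying an amine would fare on either core.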